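A thiophen-2-yl swap in compound 3

The compounds below may be only part of what the source reports. "The series", "measured", "known", "first", "only" and "open" are said of these compounds alone.

In a functional assay on THP-1 cells (Homo sapiens) for inhibition, read by sulforhodamine B assay, with a stated time of 48 h, tested at 50 uM (a higher number here means more inhibition of growth at the concentration tested, a lower number less inhibition of growth), compound 1 `COc1cc(/C=C/C(=O)/C=C/c2cccc3ccccc23)ccc1OCc1cn(CCCOc2cc(=O)oc3ccccc23)nn1` gives 71%, compound 2 `COc1ccc(/C=C/C(=O)/C=C/c2ccc(OCc3cn(CCCCOc4cc(=O)oc5ccccc45)nn3)c(OC)c2)cc1OC` gives 59% and compound 3 `COc1cc(/C=C/C(=O)/C=C/c2cccc3ccccc23)ccc1OCc1cn(CCCCOc2cc(=O)oc3ccccc23)nn1` gives 54%. Compound 3 thus sits level with compound 2 within the scatter, while compound 1 stands above compound 3 by more than the scatter.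

The next structure, compound 4 `COc1cc(/C=C/C(=O)/C=C/c2cccs2)ccc1OCc1cn(CCCCOc2cc(=O)oc3ccccc23)nn1`, differs from compound 3 in a single group: thiophen-2-yl in place of naphthalen-1-yl on a double-bonded chain carbon bound to a double-bonded chain carbon. Thiophen-2-yl takes the place of naphthalen-1-yl on a double-bonded chain carbon bound to a double-bonded chain carbon.

Going by the values given here, only one measured step touches this place: a number 5 percentage points lower from compound 2 to compound 3 (within the scatter). In that exchange, naphthalen-1-yl stood in for 3,4-dimethoxyphenyl, and the read-out did not move beyond the scatter. Among the compounds with values here, no measured compound yet carries thiophen-2-yl, so this single step is weak evidence and the range has to stay wide. Resting on that step, no change beyond the scatter is expected in this assay, and the expected move is a number 1 percentage points higher from compound 3 to compound 4 (within the scatter). Compound 4 is estimated at 55%, with an expected range from 42% to 68%.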

Compound 4, percent growth inhibition at one concentration: 44%
Compound 4: the middle estimate sits 11 percentage points above what was measured; the measured number falls inside the stated range.
By their numbers in this assay, from the lowest: compounds 4, 3 and 2 (each within the scatter of the next, the first and the last beyond it); then compound 1.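

At the double-bonded chain carbon bound to a double-bonded chain carbon, this assay records a number 10 percentage points lower from compound 3 to compound 4 (within the scatter) for thiophen-2-yl in place of naphthalen-1-yl, and a number 15 percentage points lower from compound 2 to compound 4 (beyond the scatter) for thiophen-2-yl in place of 3,4-dimethoxyphenyl. Going by these compounds alone, the earlier compounds offered only one exchange at this place, and it stayed within the scatter; the series now shows that the group carried here can shift the read-out beyond the scatter, although only across the exchange of 3,4-dimethoxyphenyl for thiophen-2-yl, with naphthalen-1-yl level with both of the others. Nothing measured on these groups accounts for this shift, so the numbers record the size of the change and give no explanation for it.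

The compounds shown leave open whether a pyridine ring, or a phenyl ring carrying an amine or a carboxylic acid, would read with compound 2 or with compound 4 at this place. They also leave open whether thiophen-2-yl would keep its standing on the chain of compound 1, which carries naphthalen-1-yl and holds the top number of the set.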